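The source may report more compounds than this note shows. Statements on the series, on what has been measured and on what is new or still open speak of the compounds shown alone.

Series notes. For the measured compounds named here, the three compounds measured so far share one core and differ only in what hangs from the oxygen on the aromatic ring. Compound 1 `CCOC(=O)C1=C(C)NC(C)=C(C(=O)OCC)C1c1ccc(OCC(=O)Nc2c(C)cccc2C)cc1` gives 53.9% in a functional assay on the whole organism (strain Wistar) for inhibition, with Rattus norvegicus as the target, read by paw edema, with stated times of 30 min and 3 h, at a dose of 20 mg/kg; a lower number here means less inhibition, a higher number more inhibition at the dose given (going by the name of the read-out). Compound 2 `CCOC(=O)C1=C(C)NC(C)=C(C(=O)OCC)C1c1ccc(OCC(=O)Nc2ccc(C)cc2)cc1` gives 61.1% in this assay, and compound 3 `CCOC(=O)C1=C(C)NC(C)=C(C(=O)OCC)C1c1ccc(OCC(=O)NNC(=O)c2ccsc2Cl)cc1` gives 53.3%. Compound 2 holds the highest of the three numbers, but the step of a number 7.2 percentage points higher from compound 1 to compound 2 (within the scatter) and the step of a number 7.8 percentage points lower from compound 2 to compound 3 (within the scatter) both sit within the scatter, as does the step of a number 0.6 percentage points lower from compound 1 to compound 3 (within the scatter), so the three compounds are not separated by these data. Compound 4 `CCOC(=O)C1=C(C)NC(C)=C(C(=O)OCC)C1c1ccc(OCc2nnc(S)o2)cc1` is not yet measured. Against compound 2 its change is 5-sulfanyl-1,3,4-oxadiazol-2-yl in place of (4-methylphenyl)carbamoyl on a saturated chain carbon bound to an oxygen on an aromatic ring. The measured steps all exchange one group for another on an amide-type nitrogen and leave the carbamoyl part in place; here the carbamoyl group itself leaves. Going by the values given here, none of the measured steps moved the number beyond the scatter. Among the compounds with values here, no measured step reaches this change directly, so the expectation rests on the absence of movement across compounds 1, 2 and 3: the step of a number 6.1 percentage points lower from compound 2 to compound 4 (within the scatter) is expected to stay within the scatter. Compound 4 is therefore estimated at 55%, with a range from 40% to 68% in this assay.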

Compound 4, a percentage reported as inhibition, in the whole organism at one dose (the size of the read-out at that dose, not a potency): 61.1%
Beside the measured number, compound 4's estimate is 6.1 percentage points below it, within the range that was stated.
By their numbers in this assay, from the lowest: compounds 3, 1, 2 and 4 (each within the scatter of the next).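

In this assay, the carbamoyl group itself can leave the saturated chain carbon bound to an oxygen on an aromatic ring without the number separating from those of the amide-bearing compounds: (no change at the digits printed from compound 2 to compound 4 (within the scatter)), (a number 7.2 percentage points higher from compound 1 to compound 4 (within the scatter)) and (a number 7.8 percentage points higher from compound 3 to compound 4 (within the scatter)). The earlier steps shown here only exchanged groups on an amide-type nitrogen, whereas here 5-sulfanyl-1,3,4-oxadiazol-2-yl replaces the whole carbamoyl unit, so at this dose a number of this size requires neither that unit nor a six-membered aromatic ring of carbon only, as compound 4 shows. No measurement at hand offers an explanation for why these quite different groups read alike at this position.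

The compounds shown leave open whether the sulfanyl group contributes to the number of compound 4, which an amine in its place on the same five-membered aromatic ring would test. They also leave open whether any ring is needed at this position, which a carboxylic acid on the saturated chain carbon would test, and all of these numbers come from a single dose, so they do not rank potency.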